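A Pyridin-4-yl Variant of Compound 2 Awaits Measurement

A few compounds are considered here, and "the series" means these few. Any claim that something is new, unique, unknown or untested is made for them only; others in the source may bear on it.

Three compounds sharing one core have been examined in a functional assay on the whole organism with Rattus norvegicus as the target, read by paw edema, at a dose of 50 mg/kg by the oral route; a higher number here means more inhibition at the dose given (going by the name of the read-out), a lower number less inhibition. Compound 1 `Cc1ccc(C2=Nn3c(nnc3-c3cc(Cl)cc(Cl)c3Cl)SC2)cc1` gives 19.4%, compound 3 `Clc1ccc(C2=Nn3c(nnc3-c3cc(Cl)cc(Cl)c3Cl)SC2)cc1` gives 30.6%, and compound 2 `Clc1cc(Cl)c(Cl)c(-c2nnc3sc(-c4ccccc4)nn23)c1` gives 16.1%. Among the compounds with values here, the only single-point step among them, a number 11.2 percentage points higher from compound 1 to compound 3 (beyond the scatter), is a chloro in place of methyl on an aromatic carbon. Compound 2 stands lowest of the three in this assay; its gap to compound 1 lies within the scatter, while compound 3 sits beyond it.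

Compound 4 `Clc1cc(Cl)c(Cl)c(-c2nnc3sc(-c4ccncc4)nn23)c1` differs from compound 2 by pyridin-4-yl in place of phenyl on an aromatic carbon. Within the data shown here, no measured step touches this position: the one known step concerns another part of the molecule and was modest. With nothing pointing in either direction, the change is expected to produce no step beyond the scatter. Compound 4 is therefore expected to give about 18% in this assay, with a range from 6% to 32%. This estimate means a step of a number 1.9 percentage points higher from compound 2 to compound 4 (within the scatter), expected to remain within the usual scatter.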

Compound 4, a percentage reported as inhibition, in the whole organism at one dose (the size of the read-out at that dose, not a potency): 11.3%
Compound 4: middle estimate off by 6.7 percentage points, on the high side, and the stated range covers the measured number.
By their numbers in this assay, from the lowest: compounds 4, 2 and 1 (each within the scatter of the next); then compound 3.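

In this assay, pyridin-4-yl in place of phenyl, on the aromatic carbon of the five-membered ring, gives a number 4.8 percentage points lower from compound 2 to compound 4 (within the scatter). At this place, then, a ring nitrogen with one hydrogen-bond acceptor enters the six-membered ring without a step beyond the scatter, something the earlier step, on another part of the molecule, could not show. No evidence on the compounds is available to account for this result.

The compounds shown leave open how an amine, a carboxylic acid or pyridin-3-yl would read at this same place, and whether any group here can move the number beyond the scatter. On these data alone, it also stays open whether a chlorophenyl here would differ from a methylphenyl as in a number 11.2 percentage points higher from compound 1 to compound 3 (beyond the scatter).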